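The compounds below may be only part of what the source reports. "The series", "measured", "known", "first", "only" and "open" are said of these compounds alone.

Measured so far in an assay on isolated protein (urine) for inhibition of Myeloperoxidase (Homo sapiens), with a stated time of 5 min; on this read-out lower numbers stand for stronger inhibition and higher numbers for weaker inhibition:
- compound 1, `NCCSCCc1c[nH]c2ccc(F)cc12`: 4 nM
- compound 2, `NC(=O)CCc1c[nH]c2c(F)cccc12`: 271 nM
- compound 3, `NCCSCCCc1c[nH]c2c(F)cccc12`: the value is a limit of this assay, > 100 nM

Compound 1 holds the lowest of the two numbers shown; the nearest number, from compound 2, is higher by a gap that lies beyond the scatter. Compound 3 gives only a limit, so the limit of > 100 nM in this assay, at which 1 of the 3 values shown sits, is all that can be said of it.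

Compound 4, `NC(=O)CCc1c[nH]c2ccc(F)cc12`, is not yet measured. It differs from compound 1 by carbamoyl in place of (2-aminoethyl)sulfanyl on a saturated chain carbon, two bonds along the chain from an aromatic carbon. Within the data shown here, the one measured step that bears on this exchange is a step that the limit leaves unreadable from compound 2 to compound 3, which the limit leaves unreadable; it also runs on the other core and is cut one bond further out, so it gives no size. What remains is the value of compound 2, which carries carbamoyl and sits well above compound 1.

For compound 4 a weaker number than compound 1 is therefore expected, with the step of a 15-fold higher number from compound 1 to compound 4 (1.18 log units; beyond the scatter). The estimate for compound 4 in this assay is 60 nM, expected to fall between 10 nM and 400 nM.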

Compound 4, half-maximal inhibitory concentration: 132 nM
The estimate for compound 4 lay 2.2-fold (0.34 log units) below the measured number, and the stated range covers the measured number.
By their numbers in this assay, from the lowest: compound 1; then compound 4; then compound 2.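

In this assay, the exchange at this position can now be sized on one core: a 33-fold higher number from compound 1 to compound 4 (1.52 log units; beyond the scatter). The earlier compounds shown here gave no readable size for this change, so this pair is the only direct measure of what replacing (2-aminoethyl)sulfanyl with carbamoyl does on a saturated chain carbon, two bonds along the chain from an aromatic carbon. The result ties the low number of compound 1 to the (2-aminoethyl)sulfanyl group on this core, although a single pair sets no general pattern for the series.

Going by these compounds, whether the exchange has a similar size on the core of compound 2 stays open, since the step to compound 3 cannot be read and compound 3 gives only a limit: the limit of > 100 nM in this assay, at which 1 of the 4 values shown sits. A plain amine or a carboxylic acid at this position would help show which part of the (2-aminoethyl)sulfanyl group carries the difference.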